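This account rests on a few compounds, and the source may have more. Where it says the series, first, only, none or still open, it means among the compounds named here.

Of the compounds shown here, two with a shared core have been measured in a functional assay on HeLa cells (Homo sapiens) for inhibition, read by CCK-8 assay, with a stated time of 72 h, tested at 2 uM; on this read-out higher numbers stand for more inhibition of growth at the one concentration tested and lower numbers for less inhibition of growth. Compound 1 `Nc1ccccc1NC(=O)c1ccc(CSc2nccc(C(F)(F)F)n2)cc1` gives 68.3% in this assay. Compound 2 `Nc1ccccc1NC(=O)/C=C/c1ccc(CSc2ccc(F)cc2)cc1` gives 7.09% in this assay, the lower of the two numbers, and compound 1 stands well above it by a gap beyond the scatter. These two compounds differ in more than one place, so nothing can be read from their gap about any single change.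

Compound 3 `Nc1ccccc1NC(=O)/C=C/c1ccc(CSc2cccc(F)c2)cc1` is not yet measured. It differs from compound 2 in one place: 3-fluorophenyl in place of 4-fluorophenyl on a sulfur. Among the measured compounds shown here, no measured pair shows what such a change does here. Since compound 2 sits low in this assay at 7.09%, only a small step is expected, in either direction or none beyond the scatter: a number 2.9 percentage points higher from compound 2 to compound 3 (within the scatter) is the expected step. Compound 3 is thus estimated at 10%, with a range from 0% to 30%.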

Compound 3, percent growth inhibition at one concentration: 2.25%
Compound 3: middle estimate off by 7.8 percentage points, on the high side; low and high end bracket the measured number.
By their numbers in this assay, from the lowest: compounds 3 and 2 (each within the scatter of the next); then compound 1.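

Among the compounds shown here, replacing 4-fluorophenyl with 3-fluorophenyl on the sulfur gives the first single-change comparison here: in this assay, the result is a number 4.8 percentage points lower from compound 2 to compound 3 (within the scatter). On this read-out, the two fluorophenyl groups therefore cannot be told apart, and moving the fluorine around this ring does not lift the low growth inhibition of compound 2. Nothing available here explains why the two compounds behave alike.

Still open, as far as these compounds go, is whether a different group on this sulfur, such as a chlorophenyl, a methoxyphenyl, a pyridine ring or a plain methyl, would give a clearly different number. Also open, from the compounds shown here alone, is whether the same fluorine shift would matter in a compound with a higher starting number, where a drop would have more room to show.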